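The source may hold more compounds than are shown below. What is called first, only, known or untested is meant among the compounds shown, and "the series" means these compounds.

Compound 1 `Cc1c(CNCc2ccccc2)cc(-c2ccc(Cl)cc2)n1-c1ccc(Cl)cc1` reads "not determined" (no result reported)
Compound 2 `Cc1cc(CNCc2ccc(Cl)cc2)c(C)n1-c1ccc(Cl)cc1` reads 0.1 ug/mL
Compound 3 `Cc1cc(CNCc2ccccc2)c(C)n1-c1ccc(Cl)cc1` reads 5.5 ug/mL

In an ADME assay on RAW264.7 cells (Mus musculus) for cytotoxicity, read by trypan blue exclusion, with a stated time of 48 h (on this read-out higher numbers stand for weaker inhibition of growth and lower numbers for stronger inhibition of growth), compound 1 gives "not determined" (no result reported) and so offers no number to start from. Compound 4 `Cc1c(CN2CCN(C)CC2)cc(-c2ccc(Cl)cc2)n1-c1ccc(Cl)cc1` differs from compound 1 as follows: 4-methylpiperazin-1-yl in place of benzylamino on a saturated chain carbon bound to an aromatic carbon. Among the compounds with values here, the only measured step is a 55-fold higher number from compound 2 to compound 3 (1.74 log units; beyond the scatter) and it is large and beyond the scatter. That step swaps chloro for hydrogen, not one amine for another, so it bears only indirectly, as a warning that small edits here can move the number far. With no value for compound 1, no size or direction of step can be expected, and the range must stay wide. In this assay compound 4 is expected at 5 ug/mL with an estimated range of 0.8 ug/mL to 30 ug/mL as a cautious guess.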

Compound 4, concentration for 50% growth inhibition: 19 ug/mL
Estimate against measurement, compound 4: 3.8-fold (0.58 log units) below, within the range that was stated.
By their numbers in this assay, from the lowest: compound 2; then compound 3; then compound 4.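

Within the data shown here, compound 1 reads "not determined" (no result reported) in this assay, so no step from compound 1 to compound 4 can be read. What exchanging benzylamino for 4-methylpiperazin-1-yl does to this read-out stays open, and no supporting data explain the values shown.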